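This account rests on a few compounds, and the source may have more. Where it says the series, first, only, none or still open, it means among the compounds named here.

Measured so far in a functional assay on the whole organism (Hindlimb, strain albino) with Mus musculus as the target, in the maximal electroshock model, with a stated time of 0.5 h (on this read-out higher numbers stand for an effect only at larger amounts of compound and lower numbers for an effect already at smaller amounts), the values are:
- compound 1 `COc1ccc(C2CC(Nc3nc4ccc(C)cc4s3)=NN2C(C)=O)cc1` gives 37.3 umol/kg
- compound 2 `O=C(/C=C/OC1=CC=C1)Nc1nc2ccc([N+](=O)[O-])cc2s1` gives 597 umol/kg
- compound 3 `COc1ccc(C2CC(Nc3nc4ccc([N+](=O)[O-])cc4s3)=NN2C(C)=O)cc1` gives 145 umol/kg

Compound 1 has the lowest of these three numbers, so it shows its effect at the smallest amount. The closest of the others is reached by a 3.9-fold higher number from compound 1 to compound 3 (0.59 log units; beyond the scatter), and compound 2 lies furthest off.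

The next compound to be tested is compound 4 `CC(=O)N1N=C(Nc2nc3ccc(C)cc3s2)CC1c1ccccc1`, which keeps the core of compound 1 and turns 4-methoxyphenyl into phenyl. The change is hydrogen in place of methoxy on an aromatic carbon, and it is hydrogen in place of methoxy, para to a large group.

For the measured compounds named here, no measured step touches this group. Going by the values given here, the only single change on record, nitro in place of methyl, sits elsewhere in the molecule. It shows that one small change can move the number by a modest amount in this series, but it does not tell which way losing methoxy will go. A step beyond the scatter is therefore not expected, and since compound 1 sits at the low end, a slight rise seems a little likelier than a fall. The expected change is a 1.3-fold higher number from compound 1 to compound 4 (0.13 log units; within the scatter), which is only an estimate. For compound 4 the estimated value is 50 umol/kg, with an expected range from 18 umol/kg to 130 umol/kg in this test.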

Compound 4, dose for half-maximal effect: 106 umol/kg
The estimate for compound 4 lay 2.1-fold (0.33 log units) below the measured number; low and high end bracket the measured number.
By their numbers in this assay, from the lowest: compound 1; then compounds 4 and 3 (each within the scatter of the next); then compound 2.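

In this assay, hydrogen in place of methoxy, para to a large group, gives a 2.8-fold higher number from compound 1 to compound 4 (0.45 log units; beyond the scatter) and so shows that this position is not indifferent: without the methoxy group, a larger amount of compound is needed for the same effect. For the compounds shown here, until now, the only single change on record was nitro in place of methyl elsewhere in the molecule, with a 3.9-fold higher number from compound 1 to compound 3 (0.59 log units; beyond the scatter) as its step, so changes at two separate places have now been read against compound 1, and both raise the number. No measurement at hand speaks to what lies behind the step caused by losing methoxy.

On these data alone, only methoxy and hydrogen can be compared at this position, so it remains open whether ethoxy, a chlorine atom or a hydroxyl group there would match compound 1, fall short of it or give a lower number. As far as these compounds go, it is also open whether swapping methoxy for hydrogen would produce a step of similar size in compound 3, which carries nitro in place of methyl.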